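A few compounds are considered here, and "the series" means these few. Any claim that something is new, unique, unknown or untested is made for them only; others in the source may bear on it.

Compound 3 `CSc1cccc(NC(=O)c2cccc(/C=C3\CC(=O)N(c4ccccc4)C3=O)c2)c1` carries a 3-(methylsulfanyl)phenyl group on the amide-type nitrogen of the shared core. In an ADME assay on NCM460 cells (Homo sapiens) for cytotoxicity, read by MTT assay, with a stated time of 72 h (on this read-out lower numbers stand for stronger inhibition and higher numbers for weaker inhibition), compound 3 gives > 100000 nM, which is a limit of the assay and not a number. Two close relatives were measured alongside it. Compound 1 `Cc1cccc(NC(=O)c2cccc(/C=C3\CC(=O)N(c4ccccc4)C3=O)c2)c1` gives > 100000 nM in this assay, again a limit. Compound 2 `O=C(Nc1ccc(Cl)cc1)c1cccc(/C=C2\CC(=O)N(c3ccccc3)C2=O)c1` gives > 100000 nM in this assay, also a limit. Because of the limit of > 100000 nM in this assay, at which 3 of the 3 values shown sit, none of the connecting steps can be sized: the step from compound 1 to compound 2 is a step that the two limits leave unreadable from compound 1 to compound 2, that from compound 1 to compound 3 is a step that the two limits leave unreadable from compound 1 to compound 3, and that from compound 2 to compound 3 is a step that the two limits leave unreadable from compound 2 to compound 3. Compound 4 `O=C(Nc1cccc(F)c1)c1cccc(/C=C2\CC(=O)N(c3ccccc3)C2=O)c1` has not been measured. Its difference from compound 3 is fluoro in place of methylsulfanyl on an aromatic carbon. Within the data shown here, no measured step bears on this exchange with a readable size, so the only guidance is that every neighbour so far sits at the same limit. The step from compound 3 to compound 4 is therefore expected to be a step that the limit leaves unreadable from compound 3 to compound 4, that is, no change beyond the scatter. Compound 4 is expected to give about 150000 nM in this assay, within 50000 nM to 500000 nM, and most likely only a limit again.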

Compound 4, half-maximal inhibitory concentration: > 100000 nM
Compound 4 ended at the assay's limit; the forecaster's own chance of this, stated with the estimate: 85%; the middle value lies beyond the limit too.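

The steps linking compound 4 to compound 1, compound 2 and compound 3 cannot be read in this assay, because all four values are limits: the limit of > 100000 nM in this assay, at which 4 of the 4 values shown sit.

The compounds shown leave open whether any exchange on the amide-type nitrogen would bring a value inside the range of the assay.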